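Fluoro on the core ring of compound 1

This account rests on a few compounds, and the source may have more. Where it says the series, first, only, none or still open, it means among the compounds named here.

For the measured compounds named here, compound 1 `COc1ccc2nc(Nc3ccnc(Nc4ccc(S(N)(=O)=O)cc4)n3)sc2c1` carries a methoxy group on the fused bicyclic part and gives 1480 nM in a functional assay on HCT-116 cells (Homo sapiens) for antiproliferative activity, read by MTT assay, with a stated time of 48 h; on this read-out higher numbers stand for weaker inhibition and lower numbers for stronger inhibition; among the two numbers so far it is the highest, the nearest being compound 2 `NS(=O)(=O)c1ccc(Nc2nccc(Nc3nc4ccc(F)cc4s3)n2)cc1` with 700 nM in this assay. Going by the values given here, the single measured step, a 2.1-fold lower number from compound 1 to compound 2 (0.33 log units; beyond the scatter), concerns the fused bicyclic part only. The unmeasured compound 3 `COc1ccc2nc(Nc3nc(Nc4ccc(S(N)(=O)=O)cc4)ncc3F)sc2c1` is compound 1 with fluoro in place of hydrogen on an aromatic carbon. Among the compounds with values here, no measured step touches this place, so the step from compound 1 to compound 2 bears on it only as a general sign that one fluorine added to the series lowered the number modestly. A step within the scatter, or a small lowering, is therefore expected for compound 3, namely a 1.5-fold lower number from compound 1 to compound 3 (0.17 log units; within the scatter). Compound 3 is estimated at 1000 nM in this assay, within 400 nM to 2500 nM.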

Compound 3, half-maximal inhibitory concentration: 11500 nM
Estimate against measurement, compound 3: 12-fold (1.06 log units) below, and the stated range ends below it.
By their numbers in this assay, from the lowest: compound 2; then compound 1; then compound 3.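

In this assay, the aromatic carbon on the six-membered aromatic ring with 2 nitrogen, ortho to a large group and para to a large group, proves sensitive to a single added atom: fluoro in place of hydrogen there gives a 7.8-fold higher number from compound 1 to compound 3 (0.89 log units; beyond the scatter). That change runs in the opposite direction to a 2.1-fold lower number from compound 1 to compound 2 (0.33 log units; beyond the scatter), so among these compounds a fluoro group does not lower the number regardless of where it sits, although that earlier step replaced methoxy rather than hydrogen. Nothing measured here accounts for the rise at this position.

The compounds shown leave open whether the rise is specific to fluoro or follows any replacement of that hydrogen, which a chloro, a methyl or an amine at the same carbon would help to separate. From the compounds shown here alone, whether the same change on compound 2 gives a rise of similar size also remains open.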